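Second fluoro on the aryl group of compound 3

The source may hold more compounds than are shown below. What is called first, only, known or untested is meant among the compounds shown, and "the series" means these compounds.

Measured so far in a functional assay for agonist activity at G protein-coupled receptor 88 (Homo sapiens), read by HTRF and cAMP accumulation; on this read-out lower numbers stand for an effect already at smaller amounts and higher numbers for an effect only at larger amounts of compound:
compound 1, `CO[C@H](C)[C@H](N)CN(C(=O)[C@@H]1C[C@H]1c1ccccc1)c1ccc(-c2ccccc2)cc1`, gives 0.68 nM
compound 2, `O=C([C@@H]1C[C@H]1c1ccccc1)N(CCNCC1CCCCC1)c1ccc(-c2ccccc2)cc1`, gives 6.6 nM
compound 3, `CC[C@H](C)[C@H](N)CN(C(=O)[C@@H]1C[C@H]1c1ccc(F)cc1)c1ccc(-c2ccccc2)cc1`, gives 600 nM

Compound 3 stands at the highest of the three numbers in this assay; compound 2 and compound 1 both give lower numbers, and each of those gaps lies beyond the scatter. Among the compounds with values here, compound 3 also differs from the other two in more than one place, so no single step is computed for it.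

Compound 4, `CC[C@H](C)[C@H](N)CN(C(=O)[C@@H]1C[C@H]1c1ccc(F)c(F)c1)c1ccc(-c2ccccc2)cc1`, is to be measured. The difference from compound 3 is fluoro in place of hydrogen on an aromatic carbon. Within the data shown here, the only computed step, a 9.7-fold higher number from compound 1 to compound 2 (0.99 log units; beyond the scatter), concerns a saturated chain carbon bound to the amide-type nitrogen and says nothing about the aromatic ring where the new fluoro enters. Among the measured compounds shown here, no measured pair shows a change on that ring. With nothing to lean on, the expectation for compound 4 is no step beyond the scatter: the estimated step of a 1.2-fold lower number from compound 3 to compound 4 (0.08 log units; within the scatter) is small and its direction is open.

Compound 4 is therefore expected to give about 500 nM in this assay, with a range of 150 nM to 2000 nM.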

Compound 4, half-maximal effective concentration: 720 nM
Compound 4: the middle estimate sits 1.4-fold (0.16 log units) below what was measured, and the stated range covers the measured number.
By their numbers in this assay, from the lowest: compound 1; then compound 2; then compounds 3 and 4 (each within the scatter of the next).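

In this assay, the change from 4-fluorophenyl to 3,4-difluorophenyl gives a 1.2-fold higher number from compound 3 to compound 4 (0.08 log units; within the scatter), so a fluoro in place of hydrogen on this aromatic carbon, ortho to a fluoro group and meta to a large group, leaves the read-out within the scatter in this pair. Within the data shown here, this is the first measured pair with a change on that aromatic ring, since the only earlier step, a 9.7-fold higher number from compound 1 to compound 2 (0.99 log units; beyond the scatter), concerns a saturated chain carbon bound to the amide-type nitrogen and not the ring. No measurement bears on why the added fluoro leaves the number within the scatter.

On these data alone, this single pair covers only fluoro at this one aromatic carbon and only with the chain carried by compound 3 and compound 4, so it remains open whether a larger entering group such as chloro, methoxy or nitrile would be accommodated as well, or whether the same change would hold with the chain of compound 1. Among these compounds, the contribution of the fluoro in the 4-fluorophenyl group also remains unresolved, as compound 3 differs from compound 1 in more than one place and no single step isolates that group.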